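The source may hold more compounds than are shown below. What is called first, only, known or untested is meant among the compounds shown, and "the series" means these compounds.

Measured so far:
compound 1 `CCN(Cc1cccc(Br)c1)c1ccc(C(=O)N2CCc3ccc(OS(N)(=O)=O)cc3C2)cc1` — 1.93
compound 2 `CCN(Cc1ccc(F)cc1)c1ccc(C(=O)N2CCc3ccc(OS(N)(=O)=O)cc3C2)cc1` — 1.93
compound 3 `CN(C)CCCN(Cc1ccccc1)c1ccc(C(=O)N2CCc3ccc(OS(N)(=O)=O)cc3C2)cc1` — 1.93

In a physicochemical assay for lipophilicity (on this read-out higher numbers stand for higher lipophilicity and lower numbers for lower lipophilicity), compound 3 stands level with compounds 1 and 2 at the digits given; all three values lie within the scatter of each other. Compound 4 `CCN(Cc1ccccc1)c1ccc(C(=O)N2CCc3ccc(OS(N)(=O)=O)cc3C2)cc1` differs from compound 3 by hydrogen in place of (dimethylamino)methyl on a saturated chain carbon, two bonds along the chain from a nitrogen on an aromatic ring. Within the data shown here, the only measured step, no change at the digits printed from compound 1 to compound 2 (within the scatter), swaps one halogenated ring for another and does not touch the chain altered here, so it bears on the present change only in showing that the shared core keeps its value when a peripheral group is exchanged. Among the measured compounds shown here, no measured step removes a chain of this kind, so the expected step is a number 0.07 log units higher from compound 3 to compound 4 (within the scatter), no change beyond the scatter. Compound 4 is therefore estimated at 2, within 1.6 to 2.4.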

Compound 4, partition coefficient: 3.08
Compound 4: the middle estimate sits 1.08 log units below what was measured, and the stated range ends below it.
By their numbers in this assay, from the lowest: compounds 1, 2 and 3 (each within the scatter of the next); then compound 4.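

In this assay this position proves far from silent: ethyl in place of 3-(dimethylamino)propyl gives a number 1.15 log units higher from compound 3 to compound 4 (beyond the scatter) on this read-out. The ring is just as sensitive, since hydrogen in place of fluoro gives a number 1.15 log units higher from compound 2 to compound 4 (beyond the scatter) and hydrogen in place of bromo gives a number 1.15 log units higher from compound 1 to compound 4 (beyond the scatter). Compounds 1 and 2 nonetheless match each other. Nothing available explains these steps. Open, on these data alone, is how a plain propyl chain, or a chain ending in a carboxylic acid, would read at this position, and how chloro would read on the ring.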